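Replacing the phenoxy terminus with a plain alkyl chain

The source may hold more compounds than are shown below. What is called first, only, known or untested is meant among the compounds shown, and "the series" means these compounds.

Measured compounds:
compound 1, `CN1CCN(c2nc3ccccc3n2CCOc2ccccc2)CC1`, 6.9 nM
compound 2, `CCOCCn1c(N2CCCN(Cc3ccccc3)CC2)nc2ccccc21`, 15 nM

Both compounds were examined in a functional assay on ileum for inhibition of histamine H1 receptor (Cavia porcellus); on this read-out higher numbers stand for weaker inhibition and lower numbers for stronger inhibition. Compound 1 gives the lower of the two numbers; compound 2 sits at a number that differs from it by more than the scatter. Within the data shown here, no single-point step between the two measured compounds is given, since they differ in more than one place, so their two values are simply what they show.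

Compound 3, `CCCCCCn1c(N2CCN(C)CC2)nc2ccccc21`, has not been measured. It departs from compound 1 by one change: butyl in place of phenoxy on a saturated chain carbon, two bonds along the chain from an aromatic nitrogen. Nothing measured here isolates this kind of exchange, so the expected step rests on the observation that both measured compounds, which carry an aromatic ring beyond the shared core, give strong inhibition, whereas compound 3 carries none. Compound 3 is therefore expected to give weaker inhibition than compound 1, with an estimated step of a 4.3-fold higher number from compound 1 to compound 3 (0.64 log units; beyond the scatter), larger than the scatter but not drastic. For compound 3 the estimated value is 30 nM, with a range from 8 nM to 120 nM.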

Compound 3, half-maximal inhibitory concentration: 26 nM
For compound 3 the middle estimate is 1.2-fold (0.06 log units) above the measured one; measured number inside the range.
By their numbers in this assay, from the lowest: compound 1; then compounds 2 and 3 (each within the scatter of the next).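

Among these compounds, exchanging phenoxy for butyl on a saturated chain carbon, two bonds along the chain from an aromatic nitrogen, gives in this assay a 3.8-fold higher number from compound 1 to compound 3 (0.58 log units; beyond the scatter), the first reading of this position in which only one place changes, and the step is modest though beyond the scatter. Compound 3, whose butyl brings no ring, still gives 26 nM, so a six-membered aromatic ring of carbon at this position is not a condition for inhibition at this level, although its departure, together with that of the oxygen, does cost some inhibition. No measurement shown here accounts for the size of this step.

The exchange removes the ring, the hydrogen-bond acceptor and part of the heavy-atom count all at once, so the compounds shown do not say which of these carries the step, and a benzyl or a methoxy group at the same place would begin to separate them. Also open, from the compounds shown here alone, is how a longer chain, or an amine at the end of the chain, would read at this position.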